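A few compounds are considered here, and "the series" means these few. Any claim that something is new, unique, unknown or untested is made for them only; others in the source may bear on it.

In an in vitro ADME assay on microsomes from liver (Homo sapiens) for pharmacokinetics, read by LC-MS, with a stated time of 10 min, tested at 1 uM (on this read-out higher numbers stand for fast clearance and lower numbers for slow clearance), three compounds with a shared core have been measured. Compound 1 `CC(C)c1ccc(NC(=O)[C@H]2CN(C)C[C@@H]2c2ccc(/C=C/C(=O)Nc3ccccc3N)cc2)cc1` gives 10 mL/min/kg, compound 2 `CN1C[C@H](C(=O)Nc2ccc(Br)cc2)[C@@H](c2ccc(/C=C/C(=O)Nc3ccccc3N)cc2)C1` gives 3 mL/min/kg and compound 3 `CN1C[C@H](C(=O)Nc2ccc(F)c(Br)c2)[C@@H](c2ccc(/C=C/C(=O)Nc3ccccc3N)cc2)C1` gives 15 mL/min/kg. Compound 3 therefore sits at the upper end of these numbers, but it cannot be told apart from compound 1, as the data show a 1.5-fold higher number from compound 1 to compound 3 (0.18 log units; within the scatter). Only compound 2 stands clearly apart.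

Compound 4 `CN1C[C@H](C(=O)Nc2ccccn2)[C@@H](c2ccc(/C=C/C(=O)Nc3ccccc3N)cc2)C1` keeps the core and changes one group: pyridin-2-yl in place of 3-bromo-4-fluorophenyl on an amide-type nitrogen. In words, this is pyridin-2-yl in place of 3-bromo-4-fluorophenyl on an amide-type nitrogen.

The measured steps that bear on this change all alter the group at this same place. Besides the step already given, they are a 3.3-fold lower number from compound 1 to compound 2 (0.52 log units; beyond the scatter) and a 5.0-fold higher number from compound 2 to compound 3 (0.70 log units; beyond the scatter). Among the compounds with values here, none of the measured compounds has a ring with a hetero atom here, so this is only a rough guide. The last of those steps shows that a different ring at this place can shift the number beyond the scatter, and compound 3 lies at the upper end of the measured numbers. A modest move toward lower clearance is therefore expected, perhaps not beyond the scatter. The estimate is a 1.9-fold lower number from compound 3 to compound 4 (0.27 log units; within the scatter). For compound 4 the estimated clearance is 8 mL/min/kg, with an expected range from 3 mL/min/kg to 20 mL/min/kg.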

Compound 4, clearance: 8 mL/min/kg
The estimate for compound 4 equals the measured number at the digits printed, within the range that was stated.
By their numbers in this assay, from the lowest: compound 2; then compounds 4, 1 and 3 (each within the scatter of the next).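

With a ring holding a hetero atom now on the amide-type nitrogen, this assay shows a 1.9-fold lower number from compound 3 to compound 4 (0.27 log units; within the scatter) for the loss of 3-bromo-4-fluorophenyl, so this swap cannot be told apart from no change. Set against 4-isopropylphenyl, pyridin-2-yl likewise gives a 1.3-fold lower number from compound 1 to compound 4 (0.10 log units; within the scatter) and stays inside the same band, while against 4-bromophenyl it gives a 2.7-fold higher number from compound 2 to compound 4 (0.43 log units; beyond the scatter) and clearly differs. At this position, then, a ring with neither bromine nor fluorine and a ring carrying both read alike, and among these four compounds only compound 2 stands apart from the rest.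

Nothing measured here explains why compound 2 stands apart from the other three. Also open, from the compounds shown here alone, is how a pyridin-3-yl ring, or a phenyl ring carrying an amine or a carboxylic acid, would read at this place, since a single ring with a hetero atom cannot show whether the position of that nitrogen matters.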